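Working notes: swapping the aryl amide on the shared core

A few compounds are considered here, and "the series" means these few. Any claim that something is new, unique, unknown or untested is made for them only; others in the source may bear on it.

Of the compounds shown here, three of a shared core have been measured in an assay (strain Wistar) for displacement of a labelled ligand from adenosine receptor A1 (Rattus norvegicus), read by scintillation counting; a lower number here means a stronger inhibitor, a higher number a weaker inhibitor. Compound 1 `O=C(Nc1nc(-c2ccccc2)nc2c1nnn2Cc1ccccc1)C1CCCCC1` gives 12 nM. Compound 2 `Nc1nc(-c2ccccc2)nc2c1nnn2Cc1ccccc1` carries hydrogen on the ring nitrogen where compound 1 carries cyclohexylcarbonyl; in this assay compound 2 gives 5.6 nM, and the step is a 2.1-fold lower number from compound 1 to compound 2 (0.33 log units; beyond the scatter). Compound 3 `Cc1ccc(C(=O)Nc2nc(-c3ccccc3)nc3c2nnn3Cc2ccccc2)cc1` gives 709 nM and stands highest of the three numbers, with compound 1 nearest and compound 2 furthest; the steps leading to it are a 59-fold higher number from compound 1 to compound 3 (1.77 log units; beyond the scatter) and a 130-fold higher number from compound 2 to compound 3 (2.10 log units; beyond the scatter).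

Compound 4 `O=C(Nc1nc(-c2ccccc2)nc2c1nnn2Cc1ccccc1)c1ccccc1F` differs from compound 3 in one place: 2-fluorophenyl in place of 4-methylphenyl on a carbonyl carbon. Going by the values given here, no measured step exchanges one aromatic ring for another on this carbonyl carbon. What the measured steps do show is that the aryl amide sits well above both the cyclohexyl amide and the free amine, and both of those steps were large. Nothing measured tells which way a change within the aryl ring itself moves the number, so no step beyond the scatter is assumed in this assay. Compound 4 is therefore expected to give an estimated 450 nM, with a range from 130 nM to 1600 nM. The expected step is a 1.6-fold lower number from compound 3 to compound 4 (0.20 log units; within the scatter).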

Compound 4, inhibition constant: 40 nM
Compound 4: the middle estimate sits 11-fold (1.05 log units) above what was measured, and the stated range ends above it.
By their numbers in this assay, from the lowest: compound 2; then compound 1; then compound 4; then compound 3.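

In this assay the aromatic ring on this carbonyl carbon does not carry a fixed penalty: with 2-fluorophenyl in place of 4-methylphenyl the step is an 18-fold lower number from compound 3 to compound 4 (1.25 log units; beyond the scatter), a large change from a swap that keeps the amide and the aromatic ring, so the substitution on the ring matters at this position at least as much as the choice between aryl and cyclohexyl. The aryl amide still does not match the two other compounds, with a 3.3-fold higher number from compound 1 to compound 4 (0.52 log units; beyond the scatter) and a 7.1-fold higher number from compound 2 to compound 4 (0.85 log units; beyond the scatter), both modest and beyond the scatter, so much of the gap that compound 3 showed to compound 1 and compound 2 belongs to the 4-methylphenyl group rather than to aryl amides in general. No measurement at hand accounts for the size or direction of this step.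

With only these two aryl groups, the loss of the methyl and the gain of the fluorine cannot be told apart. An unsubstituted phenyl would separate the two, and a chlorine or methoxy group on the ring would show whether fluorine is special here or whether other substituents give a similar number.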